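Triazole series: chloro to fluoro on the hydrazone aryl ring

The compounds below may be only part of what the source reports. "The series", "measured", "known", "first", "only" and "open" are said of these compounds alone.

Measured compounds:
compound 1 `Fc1ccccc1CSc1nnc(-c2ccncc2)n1-c1ccccc1`, 12000 nM
compound 2 `Clc1ccccc1CSc1nnc(-c2ccncc2)n1-c1ccccc1`, 13900 nM
compound 3 `O=C(CSc1nnc(-c2ccncc2)n1-c1ccccc1)N/N=C/c1ccc(Cl)cc1`, 5740 nM

All three were tested in a functional assay on HCT-116 cells (Homo sapiens) for inhibition, read by MTT assay, with a stated time of 48 h; on this read-out lower numbers stand for stronger inhibition and higher numbers for weaker inhibition. Compound 1 gives 12000 nM and compound 2 gives 13900 nM; these two differ only by fluoro in place of chloro on an aromatic carbon, and the step of a 1.2-fold lower number from compound 2 to compound 1 (0.06 log units; within the scatter) is within the scatter, so no change is read from it. Compound 3 gives 5740 nM, the lowest number of the three; its steps to compound 1 and to compound 2 are both beyond the scatter. The difference between the core of compound 3 and the core of compound 2 is not broken down here.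

Compound 4 `O=C(CSc1nnc(-c2ccncc2)n1-c1ccccc1)N/N=C/c1ccc(F)cc1` has not yet been measured in this assay. It differs from compound 3 by fluoro in place of chloro on an aromatic carbon. Among the measured compounds shown here, this is the same kind of change as the one from compound 2 to compound 1, but not the same: there the fluoro enters ortho to a large group, here it enters para to a large group, and the surrounding core is different. For the measured compounds named here, the only guide is the step of a 1.2-fold lower number from compound 2 to compound 1 (0.06 log units; within the scatter), which was within the scatter. On that basis the expected step is a 1.1-fold lower number from compound 3 to compound 4 (0.04 log units; within the scatter), a small one, and compound 4 is estimated at 5200 nM in this assay, with a range from 2600 nM to 10500 nM. The estimate rests on a single pair and carries the uncertainty that the surrounding core of compound 3 and compound 1 is not the same.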

Compound 4, half-maximal inhibitory concentration: 7040 nM
Compound 4: the middle estimate sits 1.4-fold (0.13 log units) below what was measured; the measured number falls inside the stated range.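

In this assay, fluoro in place of chloro on the core of compound 3, para to a large group, gives a 1.2-fold higher number from compound 3 to compound 4 (0.09 log units; within the scatter), so no change is read from this pair. Set beside the earlier pair, the change reads the same way on both cores, with neither step distinguishable from repeat measurement and no difference between the two steps: the same change on two cores in this assay, a 1.2-fold lower number (0.06 log units; within the scatter) from compound 2 to compound 1 and a 1.2-fold higher number (0.09 log units; within the scatter) from compound 3 to compound 4, 1.4-fold (0.15 log units) apart, within the scatter of two such steps. Among the compounds shown here, this supports carrying the exchange of chloro for fluoro between these two cores as a change without a readable effect on the number, but it rests on only two pairs, the exchange sits at a different place on the aryl ring in each, and it does not show that the same would hold on any other core or at any other place.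

As far as these compounds go, only chloro and fluoro are compared here, so it stays open whether a larger or different group in the same place, such as a methoxy, a nitrile, an amine or a carboxylic acid, would move the number beyond the scatter. Also open, from the compounds shown here alone, is which part of the difference between the core of compound 3 and the core of compound 2 goes with the lower number of compound 3, for instance whether a longer chain or a plain amide in place of the hydrazone would keep it.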